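A Methylphenyl Amine Replaces the Dichlorophenyl

This account rests on a few compounds, and the source may have more. Where it says the series, first, only, none or still open, it means among the compounds named here.

Measured so far in a functional assay on BGC-823 cells (Homo sapiens) for cytotoxicity, read by MTT assay; on this read-out lower numbers stand for stronger inhibition and higher numbers for weaker inhibition:
compound 1, `Cc1nc(Nc2cccc(Cl)c2)sc1C(=O)/C=C/c1ccccc1`, > 25000 nM (a limit of the assay)
compound 2, `Cc1ccccc1Nc1nc(C)c(C(=O)/C=C/c2ccc(Cl)cc2)s1`, > 25000 nM (a limit of the assay)
compound 3, `Cc1nc(Nc2ccc(Cl)c(Cl)c2)sc1C(=O)/C=C/c1ccccc1`, 10600 nM

Among the compounds with values here, compound 3 is the only member of this set with a number in this assay; the other two sit at a limit, as the limit of > 25000 nM in this assay, at which 2 of the 3 values shown sit, states. Compound 4, `Cc1ccccc1Nc1nc(C)c(C(=O)/C=C/c2ccccc2)s1`, has not yet been measured. It differs from compound 3 by 2-methylphenyl in place of 3,4-dichlorophenyl on a nitrogen on an aromatic ring.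

Within the data shown here, one measured step bears on this change. Going an at least 2.3-fold lower number from compound 1 to compound 3 (0.37 log units; beyond the scatter), a chloro added to the amine-bound ring moved the number down out of the limit. Compound 4 removes both chlorines from that ring and carries a 2-methylphenyl instead, so the direction of that step is reversed. Compound 2, which also carries a 2-methylphenyl on the amine nitrogen, shows only a limit in this assay. On that basis compound 4 is expected to give a higher number than compound 3, and the step of a 3.3-fold higher number from compound 3 to compound 4 (0.52 log units; beyond the scatter) is expected to exceed the scatter. Compound 4 is therefore estimated at 35000 nM in this assay, within 14000 nM to 100000 nM, with a good chance that only a limit is reported.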

Compound 4, half-maximal inhibitory concentration: > 25000 nM
Compound 4 was reported as a limit; the forecaster's own chance of this, stated with the estimate: 70%; the middle value is on the limit's open side.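

In this assay, putting 2-methylphenyl in place of 3,4-dichlorophenyl on the nitrogen gives an at least 2.3-fold higher number from compound 3 to compound 4 (0.37 log units; beyond the scatter). The earlier step showed what adding a chloro to the ring on this nitrogen does, whereas this one exchanges the whole ring group and shows that a ring with a methyl and no chlorine does not keep a measurable number in this assay. Compound 3, with its 3,4-dichlorophenyl, therefore remains the only compound here with a number, and the other three share one limit of the assay: the limit of > 25000 nM in this assay, at which 3 of the 4 values shown sit.

The steps to compound 4 from compound 1 and from compound 2 cannot be read, since both ends of each are limits. Going by these compounds, the true size of the change also stays open, and so does whether losing the two chlorines or gaining the methyl matters more, since this step does both at once; a 3,4-dimethylphenyl or a 3,4-difluorophenyl on the same nitrogen would bear on that question.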